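The source may report more compounds than this note shows. Statements on the series, on what has been measured and on what is new or still open speak of the compounds shown alone.

Of the compounds shown here, three share the same amide core and have been measured in an assay on cells for inhibition of sodium- and chloride-dependent glycine transporter 1 (Homo sapiens); on this read-out lower numbers stand for an effect already at smaller amounts and higher numbers for an effect only at larger amounts of compound. Compound 1 `COc1cc(C(F)(F)F)cc(C(F)(F)F)c1C(=O)NC1(c2ccccc2)CCCN(C2CCCC2)C1` gives 270 nM, compound 2 `COc1cc(C(F)(F)F)cc(C(F)(F)F)c1C(=O)NC1(c2ccccc2)CCCN(Cc2ccccc2)C1` gives 6700 nM, and compound 3 `CN1CCCC(NC(=O)c2ccc(C(F)(F)F)cc2C(F)(F)F)(c2ccccc2)C1` gives 540 nM. Compound 3 thus stands second highest of the three numbers: its value sits close to that of compound 1, with a gap that lies within the usual scatter, while compound 2 gives a clearly higher number than compound 3, a gap beyond the scatter. Among the measured compounds shown here, the only single-point step among the measured compounds is a 25-fold higher number from compound 1 to compound 2 (1.39 log units; beyond the scatter), which concerns the group on the ring nitrogen and not the aromatic ring of the amide.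

Compound 4 `Cc1cc(C(F)(F)F)ccc1C(=O)NC1(c2ccccc2)CCCN(C)C1` differs from compound 3 in one place: methyl in place of trifluoromethyl on an aromatic carbon. For the measured compounds named here, no measured step touches this part of the molecule, so nothing among the available numbers directly predicts its effect. With that gap in the data, the expectation for compound 4 is a modest move towards a higher number in this assay, which is expressed as a 1.7-fold higher number from compound 3 to compound 4 (0.22 log units; within the scatter). Compound 4 is therefore estimated at 900 nM, with a plausible range from 250 nM to 3500 nM.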

Compound 4, half-maximal effective concentration: 320 nM
Compound 4: the middle estimate sits 2.8-fold (0.45 log units) above what was measured, within the range that was stated.
By their numbers in this assay, from the lowest: compounds 1, 4 and 3 (each within the scatter of the next); then compound 2.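

Among the compounds shown here, replacing trifluoromethyl with methyl on this aromatic carbon, ortho to a large group and meta to a trifluoromethyl group, gives a 1.7-fold lower number from compound 3 to compound 4 (0.23 log units; within the scatter) in this assay and is the first measured step that touches the aromatic ring of the amide. On this read-out, compound 3 and compound 4 cannot be told apart, so a group of 1 heavy atom stands here in place of one of 4 heavy atoms with no difference beyond the usual scatter, whereas the change on the ring nitrogen gives a 25-fold higher number from compound 1 to compound 2 (1.39 log units; beyond the scatter) and does lie beyond it. No available evidence explains this result.

For the compounds shown here, it remains open how this aromatic carbon would respond to a group that differs more from these two, such as a chlorine atom, an amine or a carboxylic acid, since methyl and trifluoromethyl are the only groups compared here. Going by these compounds, it is also open whether the same swap would give a similar result with cyclopentyl or benzyl on the ring nitrogen.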